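Swapping the aromatic arm on the imine carbon

The compounds below may be only part of what the source reports. "The series", "measured", "known", "first", "only" and "open" are said of these compounds alone.

Compound 1 `COc1ccc(/C=N/NC(=O)Nc2ccc(Oc3ccnc4cc(OCCCN5CCCCC5)c(OC)cc34)c(F)c2)cc1`: 540 nM
Compound 2 `COc1cc2c(Oc3ccc(NC(=O)N/N=C/c4ccc(C(F)(F)F)cc4)cc3F)ccnc2cc1OCCCN1CCCCC1`: 660 nM
Compound 3 `COc1cc2c(Oc3ccc(NC(=O)N/N=C/c4ccc(N(C)C)cc4)cc3F)ccnc2cc1OCCCN1CCCCC1`: "not determined" (no result reported)

In a functional assay on A549 cells (Homo sapiens) for cytotoxicity, read by MTT assay, with a stated time of 72 h (on this read-out lower numbers stand for stronger inhibition and higher numbers for weaker inhibition), compound 1 gives 540 nM and compound 2 gives 660 nM; the step of a 1.2-fold higher number from compound 1 to compound 2 (0.09 log units; within the scatter) shows that exchanging the substituent on the aromatic ring at the imine carbon left the read-out essentially unchanged. Compound 3 has no number in this assay, so it offers no anchor of its own. Compound 4 `COc1cc2c(Oc3ccc(NC(=O)N/N=C/c4cc5ccccc5[nH]4)cc3F)ccnc2cc1OCCCN1CCCCC1` differs from compound 3 by 1H-indol-2-yl in place of 4-(dimethylamino)phenyl on a carbon with a double bond to nitrogen. Among the measured compounds shown here, no measured step covers this exchange, and the only step at that ring was within the scatter. On that basis compound 4 is expected to land near the values of compounds 1 and 2, estimated at 600 nM with a range from 200 nM to 2500 nM.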

Compound 4, half-maximal inhibitory concentration: 780 nM
For compound 4 the middle estimate is 1.3-fold (0.11 log units) below the measured one, and the stated range covers the measured number.
By their numbers in this assay, from the lowest: compounds 1, 2 and 4 (each within the scatter of the next).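

In this assay the 1H-indol-2-yl arm on a carbon with a double bond to nitrogen gives a 1.2-fold higher number from compound 2 to compound 4 (0.07 log units; within the scatter) when it replaces 4-(trifluoromethyl)phenyl and a 1.4-fold higher number from compound 1 to compound 4 (0.16 log units; within the scatter) when it replaces 4-methoxyphenyl. This position therefore holds a five-membered aromatic ring with a hydrogen-bond donor, as well as a substituted phenyl, with no change beyond the scatter. Nothing available explains this flat result. Compound 3 has no number, so its steps cannot be read. Going by these compounds, whether an arm ending in a carboxylic acid or a saturated amine would fit equally well remains open.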